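Adding a second chloro to the 4-chlorophenyl group

The source may report more compounds than this note shows. Statements on the series, on what has been measured and on what is new or still open speak of the compounds shown alone.

In an ADME assay on H9c2 cells (Rattus norvegicus) for cytotoxicity, read by resazurin assay, with a stated time of 72 h (a lower number here means that less compound is tolerated, a higher number that more compound is tolerated), compound 1 (`C/C(=N\Nc1nc(-c2ccccn2)cs1)c1ccc(Cl)c(Cl)c1`) gives 10200 nM. Compound 2 (`C/C(=N\Nc1nc(-c2ccc(Cl)cc2)cs1)c1ccc(Cl)c(Cl)c1`) gives > 50000 nM, which is a limit of the assay and not a number. The exact position of compound 2 is therefore unknown.

Compound 3 (`C/C(=N\Nc1nc(-c2ccc(Cl)c(Cl)c2)cs1)c1ccc(Cl)c(Cl)c1`) changes 4-chlorophenyl to 3,4-dichlorophenyl: chloro in place of hydrogen on an aromatic carbon. The new chloro replaces hydrogen on an aromatic carbon, ortho to a chloro group and meta to a large group.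

For the measured compounds named here, only one measured step bears on this change, and only indirectly. It is an at least 4.9-fold higher number from compound 1 to compound 2 (0.69 log units; beyond the scatter), where 4-chlorophenyl replaces pyridin-2-yl. That step is sizeable, but it does not add a chloro to a ring already carrying one, so it sets no firm direction here. No step beyond the scatter is therefore expected in this assay. A limit reading for compound 3 is also expected to be about as likely as a number, given (the limit of > 50000 nM in this assay, at which 1 of the 2 values shown sits). The expected change is an at least 1.1-fold lower number from compound 2 to compound 3 (0.04 log units; that floor lies within the scatter). Compound 3 is estimated at 45000 nM, with an expected range of 15000 nM to 100000 nM.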

Compound 3, half-maximal cytotoxic concentration: > 50000 nM
Compound 3 gave a limit, no number (the forecaster's own chance of this, stated with the estimate: 55%); middle value at least 1.1-fold (0.04 log units) away from the limit.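

In this assay compound 3 gives > 50000 nM, which is again a limit of the assay and not a number. Against the pyridin-2-yl group of compound 1, the 3,4-dichlorophenyl group gives an at least 4.9-fold higher number from compound 1 to compound 3 (0.69 log units; beyond the scatter), so a second chloro on the ring does not bring the reading back into the measurable range, and compound 1 remains the only one of the three with a number. The step between the two chlorinated compounds cannot be read, and the added chloro, ortho to a chloro group and meta to a large group, therefore has no size in this assay; the series has now largely reached the top of what can be read: the limit of > 50000 nM in this assay, at which 2 of the 3 values shown sit.

Open, from the compounds shown here alone, is how far apart compound 2 and compound 3 lie, and whether either sits close to the limit or far beyond it. Also open, going by these compounds, is whether an amine or a carboxylic acid in place of the new chloro would bring the reading down to a number, as the pyridin-2-yl group does in compound 1.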